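Amide Substituent Exchange on an Inactive Series

The compounds below may be only part of what the source reports. "The series", "measured", "known", "first", "only" and "open" are said of these compounds alone.

Compound 1 `CCc1ccc(NC(=O)c2cccc(/C=C3\CC(=O)N(c4ccccc4)C3=O)c2)cc1` — in an ADME assay on HCT-116 cells (Homo sapiens) for cytotoxicity, read by MTT assay, with a stated time of 72 h (on this read-out lower numbers stand for stronger inhibition and higher numbers for weaker inhibition), compound 1 gives > 100000 nM, a limit of the assay.
Compound 2 `CCCCCN1C(=O)C/C(=C\c2cccc(C(=O)NCCCC)c2)C1=O` — in this assay compound 2 gives > 100000 nM, again a limit.
Compound 3 `CCCCCN1C(=O)C/C(=C\c2cccc(C(=O)Nc3ccc(OC)cc3)c2)C1=O` — in this assay compound 3 gives > 100000 nM, also a limit.

All three measured compounds share one core and differ only in the group on the amide-type nitrogen and in the group on the imide nitrogen. For compound 1 the result is only a limit, not a number, and the same holds for the other two. Among the compounds with values here, the single step between two compounds that differ in one place, a step that the two limits leave unreadable from compound 2 to compound 3, puts 4-methoxyphenyl in place of butyl on an amide-type nitrogen, but its size is not readable because both values are limits; the one piece of evidence is the limit of > 100000 nM in this assay, at which 3 of the 3 values shown sit.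

Compound 4 `O=C(NCC1CCCCC1)c1cccc(/C=C2\CC(=O)N(c3ccccc3)C2=O)c1` is not yet measured. It differs from compound 1 by cyclohexylmethyl in place of 4-ethylphenyl on an amide-type nitrogen. Within the data shown here, no measured step with readable size bears on this change. Among the measured compounds shown here, since every value so far sits at the limit, the expectation for compound 4 in this assay is a further limit rather than a readable number, with a number no higher from compound 1 to compound 4 (the limit leaves the size open) expected to be essentially no step. The estimate for compound 4 is 100000 nM, within a range from 40000 nM to 300000 nM.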

Compound 4, half-maximal inhibitory concentration: > 100000 nM
Compound 4: no number, only a limit; the forecaster's own chance of this, stated with the estimate: 80%; the middle value sits exactly at the limit.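

In this assay compound 4 gives > 100000 nM, a limit and not a number. Compound 1 also stands at a limit, so no step can be read between compound 1 and compound 4. The compounds shown leave open which change to the shared core, if any, would give a readable number, and all of them offer only this: the limit of > 100000 nM in this assay, at which 4 of the 4 values shown sit.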